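From compound 2 to compound 3: amine exchange

The source may hold more compounds than are shown below. What is called first, only, known or untested is meant among the compounds shown, and "the series" means these compounds.

Measured in a functional assay on HT-22 cells (Mus musculus), read by LDH release; a lower number here means that less compound is tolerated, a higher number that more compound is tolerated:
- compound 1 `CC(C)CNC1Oc2ccc(C(=O)c3ccccc3)c(O)c2NC1(C)C`: 160 uM
- compound 2 `CC1(C)Nc2c(ccc(C(=O)c3ccccc3)c2O)OC1NC1CCCCC1`: 120 uM

Among the measured compounds shown here, only two numbers exist so far, and they lie within the scatter of each other, so compound 2 has no meaningful rank. The next compound to be measured is compound 3 `CC1(C)Nc2c(ccc(C(=O)c3ccccc3)c2O)OC1N1CCCCC1`, which carries piperidin-1-yl in place of cyclohexylamino on a saturated ring carbon.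

For the measured compounds named here, one measured step bears on this change, with cyclohexyl in place of isobutyl on an amine nitrogen: a 1.3-fold lower number from compound 1 to compound 2 (0.12 log units; within the scatter). Going by the values given here, it offers only limited guidance, since no measured compound shows the effect of exchanging cyclohexylamino for piperidin-1-yl. With that single step as the precedent, no change beyond the scatter is expected in this assay, and the uncertainty remains wide. The expected step is a 1.1-fold higher number from compound 2 to compound 3 (0.03 log units; within the scatter). For compound 3 the estimated value is 130 uM, with an expected range from 60 uM to 280 uM.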

Compound 3, half-maximal toxic concentration: 120 uM
The estimate for compound 3 lay 1.1-fold (0.03 log units) above the measured number; measured number inside the range.
By their numbers in this assay, from the lowest: compounds 2, 3 and 1 (each within the scatter of the next).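

In this assay, the exchange of cyclohexylamino, with 1 hydrogen-bond donor, for piperidin-1-yl, with 0 hydrogen-bond donors, gives no change at the digits printed from compound 2 to compound 3 (within the scatter), so on this saturated ring carbon the loss of that donor and the change from a ring of carbon only to a ring with 1 hetero atom leave the number within the scatter. The comparison with the open-chain group points the same way, with piperidin-1-yl in place of isobutylamino giving a 1.3-fold lower number from compound 1 to compound 3 (0.12 log units; within the scatter), and the three amine groups now seen at this carbon cannot be separated in this assay. No supporting data accompany this result that could account for it.

Still open, going by these compounds, is whether a group of another kind on this carbon, such as morpholin-4-yl or a carboxylic acid, would shift the number in this assay beyond the scatter. The rest of the shared core is the same in compound 1, compound 2 and compound 3, so these compounds say nothing about changes anywhere else on it.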